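Aryl exchange on the piperidine amide series, hepatocyte clearance

The compounds below may be only part of what the source reports. "The series", "measured", "known", "first", "only" and "open" are said of these compounds alone.

Compound 3 `COc1cc(F)ccc1-c1ccnc2[nH]c(C3CCN(CC(=O)N(C)C)CC3)cc12` gives 38 uL/min in an ADME assay on cells (Hepatocyte, Rattus norvegicus) for metabolic stability; a higher number here means faster removal of the compound, a lower number slower removal; this is the highest of the two numbers measured here, and the nearest is compound 2 `CNC(=O)CN1CCC(c2cc3c(-c4ccc(=O)n(C(C)C)c4)ccnc3[nH]2)CC1` at 8.9 uL/min. Compound 1 `CC(C)n1cc(-c2ccnc3[nH]c(C4CCNCC4)cc23)ccc1=O` sits at the limit of the assay with < 1 uL/min, a limit rather than a number (the limit of < 1 uL/min in this assay, at which 1 of the 3 values shown sits). Among the measured compounds shown here, the only step measured within a single change is an at least 8.9-fold higher number from compound 1 to compound 2 (0.94 log units; beyond the scatter); it concerns the amine nitrogen in the ring and leaves the aromatic group untouched. Compound 4 `CC(C)n1nc(-c2ccnc3[nH]c(C4CCN(CC(=O)N(C)C)CC4)cc23)ccc1=O` differs from compound 3 by a group of 10 heavy atoms (7 carbon, 2 nitrogen, 1 oxygen; one six-membered aromatic ring with 2 hetero atoms) in place of a group of 9 heavy atoms (7 carbon, 1 oxygen, 1 fluorine; one six-membered aromatic ring of carbon only), on an aromatic carbon. For the measured compounds named here, no measured step covers this exchange of the aromatic group; compounds 2 and 3 differ in two places, so their values can only be set side by side. Given that compound 2 gives 8.9 uL/min, the number for compound 4 is expected to move downward from compound 3, a 3.8-fold lower number from compound 3 to compound 4 (0.58 log units; beyond the scatter), though this rests on one comparison spanning two changes. Compound 4 is estimated at 10 uL/min, with a range from 4 uL/min to 25 uL/min.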

Compound 4, intrinsic clearance in a liver preparation (reported as CLH), per the amount of preparation that the assay uses in the Hepatocyte assay: 3.1 uL/min
The estimate for compound 4 lay 3.2-fold (0.51 log units) above the measured number; measured number outside the range, below it.
By their numbers in the Hepatocyte assay, from the lowest: compound 4; then compound 2; then compound 3. At a limit, below all of these: compound 1.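

In the Hepatocyte assay, the exchange of 4-fluoro-2-methoxyphenyl for the entering group gives a 12-fold lower number from compound 3 to compound 4 (1.09 log units; beyond the scatter). This shows that the aromatic group at this position, opposite the ring nitrogen, moves the number on its own with the amine side chain held fixed, whereas the earlier single step concerned only the amine nitrogen. In a physicochemical assay for acid dissociation, compound 3 gives 8 and compound 4 gives 7.6, which is a number 0.40 log units lower from compound 3 to compound 4 (beyond the scatter), so the same exchange shifts both read-outs, though a single pair cannot tie the two shifts together.

Which part of the entering group carries the step stays open, as does where a plain phenyl or a pyridine ring would fall at this position. Also open, on these data alone, is whether the step holds with a carboxylic acid in place of the amide on the chain at the ring amine nitrogen.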